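A Longer Chain and an Expected Cytotoxicity Step

The compounds below may be only part of what the source reports. "The series", "measured", "known", "first", "only" and "open" are said of these compounds alone.

Compound 1, `Cc1cc(-c2nc3cc(Cl)ccc3o2)ccc1NC(=O)CN1CCN(CCN(C)C)CC1`, in a functional assay on HepG2 cells (Homo sapiens) for cytotoxicity, read by MTT assay, with a stated time of 24 h (a higher number here means a weaker inhibitor, a lower number a stronger inhibitor), gives 3880 nM.
Compound 2, `CN(C)CCCN1CCN(CC(=O)Nc2ccc(-c3nc4cc(F)ccc4o3)cc2)CC1`, gives 9180 nM in this assay.
Compound 3, `CN(C)CCN1CCN(CC(=O)Nc2ccc(-c3nc4cc(F)ccc4o3)cc2)CC1`, gives 18800 nM in this assay.

Compound 1 stands lowest of the three, and its steps to compound 2 and to compound 3 both lie beyond the scatter. Compounds 2 and 3 share one core; the difference between that core and the core of compound 1 is not broken down here. Between compound 3 and compound 2 the change is (dimethylamino)methyl in place of dimethylamino on a saturated chain carbon, two bonds along the chain from an amine nitrogen in a ring, and it gave a 2.0-fold lower number from compound 3 to compound 2 (0.31 log units; beyond the scatter).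

Compound 4, `Cc1cc(-c2nc3cc(Cl)ccc3o2)ccc1NC(=O)CN1CCN(CCCN(C)C)CC1`, has not yet been measured in this assay. It differs from compound 1 by (dimethylamino)methyl in place of dimethylamino on a saturated chain carbon, two bonds along the chain from an amine nitrogen in a ring, the same change that separates compound 3 from compound 2, now made on the core of compound 1. Among the compounds with values here, since the one measured instance of this change moved the number by a 2.0-fold lower number from compound 3 to compound 2 (0.31 log units; beyond the scatter), a step of about the same size is expected from compound 1 to compound 4, a 1.9-fold lower number from compound 1 to compound 4 (0.29 log units; within the scatter). That expectation rests on a single pair and is held loosely. Compound 4 is therefore estimated at 2000 nM, with a likely range from 1000 nM to 4500 nM.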

Compound 4, half-maximal inhibitory concentration: 11200 nM
The estimate for compound 4 lay 5.6-fold (0.75 log units) below the measured number; measured number above the stated range.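

Moving from dimethylamino to (dimethylamino)methyl on the core of compound 1 did not repeat the earlier result: in this assay the change gave a 2.9-fold higher number from compound 1 to compound 4 (0.46 log units; beyond the scatter), so the number rose where it had fallen on the other core. Within the data shown here, the two steps run in opposite directions, which shows that in this small set the effect of this change did not carry from one core to the other: the same change on two cores in this assay, a 2.0-fold lower number (0.31 log units; beyond the scatter) from compound 3 to compound 2 and a 2.9-fold higher number (0.46 log units; beyond the scatter) from compound 1 to compound 4, 5.9-fold (0.77 log units) apart, beyond the scatter of two such steps This does not show which difference between the cores goes with the reversal, nor does it give a general rule, as each core supplies only a single pair.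

The compounds shown leave open whether the chlorine, the fluorine or the methyl group is what separates the two outcomes, as these features are not varied alone. They also leave open how a still longer chain, or a piperidine in place of the dimethylamino end, would read in this assay on either core.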